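A Ring Opened at a Quiet Position

A few compounds are considered here, and "the series" means these few. Any claim that something is new, unique, unknown or untested is made for them only; others in the source may bear on it.

In an ADME assay on NCM460 cells (Homo sapiens) for cytotoxicity, read by CCK-8 assay, with a stated time of 48 h (on this read-out lower numbers stand for stronger inhibition and higher numbers for weaker inhibition), compound 3 (`COc1ccc(/C=C\c2cc(OC)c(OC)c(OC)c2)cc1OCc1ccc(CN2CC[C@@H](C(=O)O)C2)cc1`) stands at > 50000 nM as a limit of the assay, not a number. Compound 1 (`COc1ccc(/C=C\c2cc(OC)c(OC)c(OC)c2)cc1OCc1ccc(CO)cc1`) gives > 50000 nM as a limit too. Compound 2 (`COc1ccc(/C=C\c2cc(OC)c(OC)c(OC)c2)cc1OCc1ccc(CNCCN(C)C)cc1`) gives 35000 nM as a measured number. Compound 3 thus sits at the limit of > 50000 nM in this assay, at which 2 of the 3 values shown sit, in this small set.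

Compound 4 (`COc1ccc(/C=C\c2cc(OC)c(OC)c(OC)c2)cc1OCc1ccc(CN[C@H](C(=O)O)[C@@H](C)O)cc1`) carries (1-carboxy-2-hydroxypropyl)amino in place of 3-carboxypyrrolidin-1-yl on a saturated chain carbon bound to an aromatic carbon. The steps at this same place bear on it: an at least 1.4-fold lower number from compound 1 to compound 2 (0.15 log units; that floor lies within the scatter) and an at least 1.4-fold higher number from compound 2 to compound 3 (0.15 log units; that floor lies within the scatter) are both floors within the scatter, and a step that the two limits leave unreadable from compound 1 to compound 3 adds nothing readable. In this assay no step beyond the scatter is therefore expected, and a step that the limit leaves unreadable from compound 3 to compound 4 is the estimate. Compound 4 is estimated at 55000 nM within a range of 30000 nM to 100000 nM and may well return only a limit.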

Compound 4, half-maximal inhibitory concentration: > 50000 nM
Compound 4: only a limit was reported; the forecaster's own chance of this, stated with the estimate: 75%; the middle value does not contradict the limit.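

Compound 4 also returns only a limit, not a number: the limit of > 50000 nM in this assay, at which 3 of the 4 values shown sit. A carboxylic acid at this place therefore goes with the limit both in the five-membered ring of compound 3 and in the open chain of compound 4, although the steps among the compounds at the limit cannot be read. Going by these compounds alone, the one readable step is an at least 1.4-fold higher number from compound 2 to compound 4 (0.15 log units; that floor lies within the scatter).

The compounds shown leave open how a primary amine or a longer chain ending in a carboxylic acid would read on this saturated chain carbon. Going by these compounds, whether any group here gives a step beyond the scatter also remains open.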